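Ethyl in place of the pyrazole on the amide nitrogen

This account rests on a few compounds, and the source may have more. Where it says the series, first, only, none or still open, it means among the compounds named here.

Compound 1, `COc1ccc(OCC(=O)N(Cc2cccs2)c2ccn[nH]2)cc1`: 3.7 nM
Compound 2, `COc1ccc2oc(C(=O)N(Cc3cccs3)c3ccn[nH]3)cc2c1`: 1.1 nM
Compound 3, `CCN(Cc1cccs1)C(=O)COc1ccc(OC)cc1`: 120 nM

In an assay on HEK293 cells for agonist activity at transient receptor potential cation channel subfamily M member 8 (Homo sapiens), read by fluorescence and calcium flux, with a stated time of 15 min (on this read-out lower numbers stand for an effect already at smaller amounts and higher numbers for an effect only at larger amounts of compound), compound 2 gives the lowest of the three values, and the difference between its core and the core of compound 1 is not broken down here. Compound 3 differs from compound 1 by ethyl in place of 1H-pyrazol-5-yl on an amide-type nitrogen, a change that produced a 32-fold higher number from compound 1 to compound 3 (1.51 log units; beyond the scatter). Compound 4, `CCN(Cc1cccs1)C(=O)c1cc2cc(OC)ccc2o1`, has not yet been measured; it differs from compound 2 by ethyl in place of 1H-pyrazol-5-yl on an amide-type nitrogen, the same change at the same kind of place, which occurs twice among the four compounds.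

Among the compounds with values here, since the shared core of compound 2 and compound 4 is not the one on which the change has been measured, the step from compound 1 to compound 3 is the only guide. For compound 4 the expected step is a 32-fold higher number from compound 2 to compound 4 (1.50 log units; beyond the scatter), resting on a 32-fold higher number from compound 1 to compound 3 (1.51 log units; beyond the scatter). Compound 4 is therefore estimated at 35 nM in this assay. The expected range for compound 4 runs from 10 nM to 120 nM.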

Compound 4, half-maximal effective concentration: 80 nM
Compound 4: the middle estimate sits 2.3-fold (0.36 log units) below what was measured; the measured number falls inside the stated range.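

In this assay, ethyl in place of 1H-pyrazol-5-yl on the amide-type nitrogen again gave a large step on the core of compound 2, a 73-fold higher number from compound 2 to compound 4 (1.86 log units; beyond the scatter). Set beside the earlier step, the change carried over from one core to the other with no difference that can be told from the scatter: the same change on two cores in this assay, a 32-fold higher number (1.51 log units; beyond the scatter) from compound 1 to compound 3 and a 73-fold higher number (1.86 log units; beyond the scatter) from compound 2 to compound 4, 2.2-fold (0.35 log units) apart, within the scatter of two such steps. This shows that the step held on these two cores only; it does not show that it would hold on a third core, nor which difference between the two groups matters, since the ring, the size and the hydrogen-bond donor and acceptor all leave together.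

The compounds shown leave open whether a longer chain, an amine or a carboxylic acid on that nitrogen would give numbers closer to those of compound 1 and compound 2 or to those of compound 3 and compound 4. They also leave open whether a smaller ring on that nitrogen would keep the low numbers.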